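The compounds below may be only part of what the source reports. "The series", "measured", "known", "first", "only" and "open" are said of these compounds alone.

Values from a functional assay on HL-60 cells (Homo sapiens) for antiproliferative activity, with a stated time of 72 h (a lower number here means a stronger inhibitor, a higher number a weaker inhibitor), follow
- Compound 1 `COC(=O)CN(C)Cc1c(OC)cc(OC)c(C(=O)/C=C/c2ccccc2Cl)c1O` gives 400 nM
- Compound 2 `COc1cc(OC)c(C(=O)/C=C/c2ccccc2Cl)c(O)c1CN(C)CC(=O)O` gives 80300 nM
- Compound 3 `COc1cc(O)c2c(=O)cc(-c3ccccc3Cl)oc2c1CN1CCCCC1` gives 48100 nM

Compound 2 stands at the high end of these numbers, level within the scatter with compound 3. It lies far from compound 1, and the large step of a 200-fold higher number from compound 1 to compound 2 (2.30 log units; beyond the scatter) marks that distance. Within the data shown here, this step comes from hydrogen in place of methyl on an oxygen, and it is the only measured step that bears on the next change.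

Compound 4 `CCN(CC)Cc1c(OC)cc(OC)c(C(=O)/C=C/c2ccccc2Cl)c1O` is reached from compound 2 by one change diethylamino in place of (carboxymethyl)(methyl)amino on a saturated chain carbon bound to an aromatic carbon on a saturated chain carbon bound to an aromatic carbon. That removes the carboxymethyl hydrogen that sets compound 2 apart from compound 1, so a sizeable move to a lower number is expected in this assay. Caution is needed, since compound 3 has a different core and no carboxymethyl group, yet gives 48100 nM as its value. Among the measured compounds shown here, no measured compound carries diethylamino. The estimated change is a 40-fold lower number from compound 2 to compound 4 (1.60 log units; beyond the scatter) and it is expected to be large. For compound 4 the estimated value is 2000 nM with an expected range from 350 nM to 12000 nM.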

Compound 4, half-maximal inhibitory concentration: 30900 nM
Compound 4: the middle estimate sits 15-fold (1.19 log units) below what was measured, and the stated range ends below it.
By their numbers in this assay, from the lowest: compound 1; then compounds 4, 3 and 2 (each within the scatter of the next, the first and the last beyond it).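

In this assay, replacing the (carboxymethyl)(methyl)amino group with diethylamino on a saturated chain carbon bound to an aromatic carbon gives only a 2.6-fold lower number from compound 2 to compound 4 (0.41 log units; beyond the scatter). Losing the carboxylic acid is therefore not enough to reach the low number of the methyl ester, as replacing the ((methoxycarbonyl)methyl)(methyl)amino group with diethylamino gives a 77-fold higher number from compound 1 to compound 4 (1.89 log units; beyond the scatter), so at this position the two amine groups are far from interchangeable. Nothing available explains this gap.

Going by these compounds, it remains open whether the low number depends on the methyl ester itself or would also hold with an ethyl ester or a primary amide on the same chain. A ring amine such as morpholine, placed at this position on the core of compound 1, is also untested among the compounds shown here.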